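The compounds below may be only part of what the source reports. "The series", "measured", "known", "first", "only" and "open" are said of these compounds alone.

Working notes on the series: in a functional assay on HepG2 cells (Homo sapiens) for cytotoxicity, read by MTT assay, with a stated time of 72 h (on this read-out lower numbers stand for stronger inhibition and higher numbers for weaker inhibition), compound 1 (`COc1cc2ncnc(Nc3ccc(F)c(Cl)c3)c2cc1NC(=O)N/N=C/c1ccc(F)cc1Cl`) gives 29200 nM, compound 2 (`COc1cc2ncnc(Nc3ccc(F)c(Cl)c3)c2cc1NC(=O)N/N=C/c1cccc(Cl)c1Cl`) gives 26100 nM and compound 3 (`COc1cc2ncnc(Nc3ccc(F)c(Cl)c3)c2cc1NC(=O)N/N=C/c1ccc(OC)c(OC)c1OC`) gives 31200 nM. Compound 3 stands level with the other two, as the steps show: a 1.1-fold higher number from compound 1 to compound 3 (0.03 log units; within the scatter) and a 1.2-fold higher number from compound 2 to compound 3 (0.08 log units; within the scatter). The remaining step is a 1.1-fold lower number from compound 1 to compound 2 (0.05 log units; within the scatter), so the three measured compounds cannot be separated on these numbers.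

Compound 4 (`COc1cc2ncnc(Nc3ccc(F)c(Cl)c3)c2cc1NC(=O)N/N=C/c1cc(OC)c(OC)c(OC)c1`) is the next to be read. It has 3,4,5-trimethoxyphenyl in place of 2,3,4-trimethoxyphenyl on a carbon with a double bond to nitrogen. The rest of the structure is shared with compound 3.

All three measured steps are exchanges at this same place, and each stays within the scatter. None of them, however, tests the same groups joined differently, so the data give only indirect guidance on this change. Because a 1.2-fold higher number from compound 2 to compound 3 (0.08 log units; within the scatter) is a step of this small size, and the other two are alike, no shift beyond the scatter is expected in this assay.

The expected change is a 1.1-fold lower number from compound 3 to compound 4 (0.03 log units; within the scatter). The estimate for compound 4 is 29000 nM, with an expected range of 14000 nM to 55000 nM.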

Compound 4, half-maximal inhibitory concentration: 30100 nM
Estimate against measurement, compound 4: 1.0-fold (0.02 log units) below; the range from low to high includes it.
By their numbers in this assay, from the lowest: compounds 2, 1, 4 and 3 (each within the scatter of the next).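

Among these compounds, compound 4 gives the first comparison here of the same atoms joined differently: 3,4,5-trimethoxyphenyl in place of 2,3,4-trimethoxyphenyl on a carbon with a double bond to nitrogen gives a 1.0-fold lower number from compound 3 to compound 4 (0.02 log units; within the scatter) in this assay and so does not separate this pair of isomeric groups. The comparisons with the two halogenated phenyl groups, a 1.2-fold higher number from compound 2 to compound 4 (0.06 log units; within the scatter) and a 1.0-fold higher number from compound 1 to compound 4 (0.01 log units; within the scatter), add to this, so all four groups at this place stand level in this assay and no compound shown goes against that flat picture. No measurement shown offers an explanation for these level numbers.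

On these data alone, all four compounds carry a substituted phenyl group with only halogen or methoxy substituents at this place, so it remains open whether a carboxylic acid or a dimethylamino group on that phenyl group would move the number beyond the scatter. The compounds shown also share one core and one linking chain, which leaves open how far changes to either would alter the read-out in this assay.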